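The source may report more compounds than this note shows. Statements on the series, on what has been measured and on what is new or still open speak of the compounds shown alone.

Measured so far:
- compound 1, `CNC(=O)N1CCCc2ccc(NC(=O)c3ccc(-c4ccn(C(C)=O)n4)cc3)cc21`, 35.8%
- compound 2, `CNC(=O)N1CCCc2ccc(NC(=O)c3ccc(-c4ccn(S(C)(=O)=O)n4)cc3)cc21`, 8.81%
- compound 3, `CNC(=O)N1CCCc2ccc(NC(=O)c3ccc(-c4cnn(S(C)(=O)=O)c4)cc3)cc21`, 4.5%

All three were run in a functional assay on MV4-11 cells (Homo sapiens) for antiproliferative activity, with a stated time of 6 days, tested at 1.56 uM; a higher number here means a stronger effect of the compound at the concentration tested, a lower number a weaker effect. Compound 1 gives 35.8% and compound 2 gives 8.81%, so the step of a number 27 percentage points higher from compound 2 to compound 1 (beyond the scatter), the change being (acetyl in place of methylsulfonyl on an aromatic nitrogen). Compound 3 gives 4.5%; against compound 1 the step is a number 31.3 percentage points lower from compound 1 to compound 3 (beyond the scatter), and against compound 2 it is a number 4.3 percentage points lower from compound 2 to compound 3 (within the scatter), which is within the scatter, so compound 2 and compound 3 are not separated here. The two cores differ as follows: 1-(methylsulfonyl)-1H-pyrazol-4-yl in place of 1-(methylsulfonyl)-1H-pyrazol-3-yl on an aromatic carbon.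

Compound 4, `CNC(=O)N1CCCc2ccc(NC(=O)c3ccc(-c4cnn(C(C)=O)c4)cc3)cc21`, has not been measured in this assay. It differs from compound 3 by acetyl in place of methylsulfonyl on an aromatic nitrogen. Within the data shown here, this is the same change as the one made from compound 2 to compound 1, made on the core of compound 3 rather than on the core of compound 2; the place is described in the same words for both.

The expectation for compound 4 rests on one step only. Because a number 27 percentage points higher from compound 2 to compound 1 (beyond the scatter) was beyond the scatter, and because a number 4.3 percentage points lower from compound 2 to compound 3 (within the scatter) shows that compound 2 and compound 3 stand together, the step from compound 3 to compound 4 is expected to be a number 23.5 percentage points higher from compound 3 to compound 4 (beyond the scatter), close to the earlier one. Compound 4 is accordingly estimated at 28% in this assay, with a range of 10% to 45%, the range being wide since it comes from a single pair.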

Compound 4, a percentage reported as inhibition, at one concentration (the size of the read-out at that concentration, not a potency): 23.9%
Compound 4: middle estimate off by 4.1 percentage points, on the high side; the measured number falls inside the stated range.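

In this assay, acetyl in place of methylsulfonyl on an aromatic nitrogen again gives a higher number on the second core, a number 19.4 percentage points higher from compound 3 to compound 4 (beyond the scatter), and the change carries across the two cores in direction and in size: the same change on two cores in this assay, a number 27 percentage points higher (beyond the scatter) from compound 2 to compound 1 and a number 19.4 percentage points higher (beyond the scatter) from compound 3 to compound 4, 7.6 percentage points apart, within the scatter of two such steps. The two acetyl compounds remain separated, a number 11.9 percentage points lower from compound 1 to compound 4 (beyond the scatter), so 1-acetyl-1H-pyrazol-4-yl does not simply reproduce 1-acetyl-1H-pyrazol-3-yl, while a number 15.1 percentage points higher from compound 2 to compound 4 (beyond the scatter) combines the change of group with the change of attachment and cannot be assigned to either one alone. This rests on two pairs read at a single concentration in one cell assay, so it shows neither a shift in potency nor a rule for cores beyond these two, and it gives no reason why acetyl reads higher than methylsulfonyl.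

The compounds shown leave open how the same nitrogen would read with other groups, such as a simple methyl, a propanoyl or a longer acyl chain, and hence whether the step is specific to acetyl. On these data alone, the rest of the shared core stays constant throughout, so it is also open whether the step would hold with an amine or a longer chain placed elsewhere on it.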